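The compounds below may be only part of what the source reports. "The series", "measured", "known", "first", "only" and "open" are said of these compounds alone.

The compounds measured so far in an assay on isolated protein for inhibition of Myeloperoxidase (Homo sapiens); a lower number here means a stronger inhibitor, a higher number a weaker inhibitor:

Compound 1 `CN1CCN(Cc2c[nH]c3ccc(F)cc23)CC1`: in this assay compound 1 gives > 1000 nM, which is a limit of the assay and not a number.
Compound 2 `NCCCc1c[nH]c2ccc(F)cc12`: in this assay compound 2 gives 650 nM.
Compound 3 `CNCCCc1c[nH]c2ccc(F)cc12`: in this assay compound 3 gives 26 nM.

Among the two numbers shown, compound 2 stands highest, meaning it is the weaker inhibitor of the pair; its nearest neighbour is compound 3, and the step of a 25-fold lower number from compound 2 to compound 3 (1.40 log units; beyond the scatter) separates them. The third value, that of compound 1, is only a limit.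

Compound 4 `CCNCCCc1c[nH]c2ccc(F)cc12` differs from compound 2 in one place: ethyl in place of hydrogen on an amine nitrogen. Among the compounds with values here, the single measured step that bears on this change is a 25-fold lower number from compound 2 to compound 3 (1.40 log units; beyond the scatter), where the group entering on the same amine nitrogen was methyl rather than ethyl. That step was large and went beyond the scatter, so a step of similar size and in the same direction is expected here, a 16-fold lower number from compound 2 to compound 4 (1.21 log units; beyond the scatter), with some allowance for the longer chain giving a somewhat different number. For compound 4 the expected value is therefore 40 nM, estimated to fall between 12 nM and 130 nM.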

Compound 4, half-maximal inhibitory concentration: 190 nM
Beside the measured number, compound 4's estimate is 4.8-fold (0.68 log units) below it, and the stated range ends below it.
By their numbers in this assay, from the lowest: compound 3; then compound 4; then compound 2. At a limit, above all of these: compound 1.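

In this assay, ethyl on the amine nitrogen still improves on the plain amine, with a 3.4-fold lower number from compound 2 to compound 4 (0.53 log units; beyond the scatter). Yet lengthening methyl to ethyl gives back much of that gain, with a 7.3-fold higher number from compound 3 to compound 4 (0.86 log units; beyond the scatter). So what matters at this nitrogen is not merely that a group replaces the hydrogen: among these three compounds methyl gives the lowest number, and even this small extension of the group moves the number beyond the scatter.

Nothing shown here explains why ethyl falls short of methyl. Going by these compounds, it remains open whether a longer chain such as propyl, or a cyclopropyl ring on the same nitrogen, would raise the number further, and whether a second methyl on that nitrogen, giving a dimethylamine, would keep the gain seen with compound 3.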